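This account rests on a few compounds, and the source may have more. Where it says the series, first, only, none or still open, it means among the compounds named here.

In a functional assay on NCI-H460 cells (Homo sapiens) for inhibition (a higher number here means a weaker inhibitor of growth, a lower number a stronger inhibitor of growth), compound 1 (`Nc1ccc(-c2nc3ccc(F)cc3s2)cc1I`) gives > 100000 nM, which is a limit of the assay and not a number. It is the only one of the three measured compounds that stands at a limit. The other two give numbers: compound 2 (`Cc1cc(-c2nc3c(F)cccc3s2)ccc1N`), which carries a methyl, gives 1000 nM, and compound 3 (`Nc1ccc(-c2nc3cc(F)ccc3s2)cc1`), which carries neither methyl nor iodo, gives 870 nM. These two values lie within the usual scatter of each other.

The step of interest leads to compound 4 (`Cc1cc(-c2nc3ccc(F)cc3s2)ccc1N`), which has not yet been measured. The change is methyl in place of iodo on an aromatic carbon, ortho to an amino group and meta to a large group. For the measured compounds named here, no measured pair of compounds isolates this change, so any expectation rests on indirect comparison. Compound 2, at 1000 nM, shows that a methyl-bearing compound can give a measured number in this assay. A large step towards stronger inhibition of growth is therefore expected, estimated as an at least 100-fold lower number from compound 1 to compound 4 (2.00 log units; beyond the scatter). The uncertainty remains wide. For compound 4 the estimated value is 1000 nM, with an expected range from 200 nM to 10000 nM.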

Compound 4, concentration for 50% growth inhibition: 100 nM
Compound 4: middle estimate off by 10-fold (1.00 log units), on the high side, outside the stated range (below it).
By their numbers in this assay, from the lowest: compound 4; then compounds 3 and 2 (each within the scatter of the next). At a limit, above all of these: compound 1.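

With the rest of the structure unchanged, methyl in place of iodo on an aromatic carbon, ortho to an amino group and meta to a large group, gives in this assay an at least 1000-fold lower number from compound 1 to compound 4 (3.00 log units; beyond the scatter). For the compounds shown here, this is the first pair that isolates this position, and it shows that this single change separates a compound with a measured number from one without, a step larger than the earlier, indirect comparison could show. Compound 1 gives > 100000 nM, which is a limit of the assay and not a number, so the step gives a minimum and not a measured size: the limit of > 100000 nM in this assay, at which 1 of the 4 values shown sits.

The compounds shown leave open whether the step comes with the arrival of the methyl or the departure of the iodo, as none of them carries hydrogen on this carbon with the rest of compound 4 unchanged. They also leave open how a chloro, an ethyl or a methoxy group on the same carbon would read in this assay, and so whether methyl is a special case or one of several groups that give a measured number here.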